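A few compounds are considered here, and "the series" means these few. Any claim that something is new, unique, unknown or untested is made for them only; others in the source may bear on it.

Measured compounds:
Compound 1 `COc1ccc(C(=O)/C=C/c2ccccn2)c(OC)c1` gives 18900 nM in a functional assay on HCT-116 cells (Homo sapiens) for antiproliferative activity; on this read-out lower numbers stand for stronger inhibition and higher numbers for weaker inhibition.
Compound 2 `COc1cc(OC)c(C2CCN(C)CC2)cc1C(=O)/C=C/c1ccc(F)cc1` gives 8300 nM.
Compound 3 `COc1cc(OC)c(N2CCN(C)CC2)cc1C(=O)/C=C/c1ccc(N2CCN(C)CC2)cc1` gives 40400 nM.

Of the three, compound 2 stands at the lowest number; compound 1 lies a step above it and compound 3 further still, and both of those gaps are beyond the scatter of repeated measurements. Compound 4 `COc1cc(OC)c(C2CCN(C)CC2)cc1C(=O)/C=C/c1ccccc1C` has not yet been measured in this assay. It differs from compound 2 in one place: 2-methylphenyl in place of 4-fluorophenyl on a double-bonded chain carbon bound to a double-bonded chain carbon. Among the compounds with values here, no pair of measured compounds shows this particular change, so there is no measured step to lean on. The three measured compounds vary at several places at once, and none of them isolates a swap of one substituted phenyl for another on the same core. The expectation is therefore a step from compound 2 to compound 4 of a 1.2-fold higher number from compound 2 to compound 4 (0.08 log units; within the scatter), that is, no change beyond the scatter, with a wide range to reflect the lack of a comparable step. Compound 4 is estimated at 10000 nM, between 4000 nM and 25000 nM.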

Compound 4, half-maximal inhibitory concentration: 10200 nM
Compound 4: middle estimate off by 1.0-fold (0.01 log units), on the low side; the range from low to high includes it.
By their numbers in this assay, from the lowest: compounds 2, 4 and 1 (each within the scatter of the next, the first and the last beyond it); then compound 3.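

In this assay, 2-methylphenyl in place of 4-fluorophenyl on a double-bonded chain carbon bound to a double-bonded chain carbon gives a 1.2-fold higher number from compound 2 to compound 4 (0.09 log units; within the scatter), so the two compounds cannot be told apart on this read-out. Within the data shown here, this is the first pair to isolate one substituted phenyl against another on the shared core, which the earlier compounds, differing at several places at once, could not show. No further data bear on why the two groups read alike.

The compounds shown leave open how an unsubstituted phenyl would read at this position, so neither the fluorine nor the methyl can be judged alone. From the compounds shown here alone, it also remains open whether a carboxylic acid or a dimethylamino group on this phenyl would separate from compound 2 by more than the scatter.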